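The source may report more compounds than this note shows. Statements on the series, on what has been measured and on what is new or still open speak of the compounds shown alone.

The measured compounds in a functional assay on MDA-MB-231 cells (Homo sapiens) for cytotoxicity, read by MTT assay, with a stated time of 72 h; on this read-out higher numbers stand for weaker inhibition and lower numbers for stronger inhibition:
compound 1 `CN(C)CCCNc1nc(-c2ccc(NC(=O)Nc3ccccc3F)cc2)nc2ccsc12` gives 660 nM;
compound 2 `CN(C)CCCNc1nc(-c2ccc(NC(=O)Nc3ccc(Cl)cc3Cl)cc2)nc2ccsc12` gives 1860 nM;
compound 3 `CN(C)CCNc1nc(-c2ccc(NC(=O)Nc3ccc(F)cc3)cc2)nc2c(Cl)c(Cl)sc12` gives 1240 nM.

Compound 2 has the highest of the three numbers, which on this read-out means the weakest inhibition. Compound 3 sits close to it, within the scatter, so the two cannot be told apart; compound 1 stands clearly lower, the step of a 2.8-fold higher number from compound 1 to compound 2 (0.45 log units; beyond the scatter) being beyond the scatter. That step, however, exchanges the aromatic ring on the urea and says nothing about the chain.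

Compound 4 `CN(C)CCNc1nc(-c2ccc(NC(=O)Nc3ccc(Cl)cc3Cl)cc2)nc2ccsc12` differs from compound 2 in a single place: dimethylamino in place of (dimethylamino)methyl on a saturated chain carbon, two bonds along the chain from a nitrogen on an aromatic ring. In plain terms, the chain linking the nitrogen on the aromatic ring to the dimethylamino group is shortened. Within the data shown here, no measured pair isolates this change: compound 3 carries the shorter chain, but it also differs in the ring on the urea and in the substituents on the core, so the values of compound 3 and compound 2 only show two numbers within the scatter of each other. With nothing that bears on the change, the expectation in this assay is a step of no set direction and no size beyond the scatter, expected as a 1.2-fold lower number from compound 2 to compound 4 (0.07 log units; within the scatter). Compound 4 is therefore estimated at 1600 nM, within a range from 700 nM to 3600 nM.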

Compound 4, half-maximal inhibitory concentration: 2450 nM
Compound 4: the middle estimate sits 1.5-fold (0.19 log units) below what was measured; measured number inside the range.
By their numbers in this assay, from the lowest: compounds 1, 3, 2 and 4 (each within the scatter of the next, the first and the last beyond it).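

In this assay the 3-(dimethylamino)propyl chain of compound 2 becomes the 2-(dimethylamino)ethyl chain of compound 4, and this gives a 1.3-fold higher number from compound 2 to compound 4 (0.12 log units; within the scatter) with the 2,4-dichlorophenyl ring on the urea and the shared core left as they were. Among these compounds, this is the first pair in which chain length is the only difference, something that compound 3 could not show, as it also differs in the ring on the urea and on the core. The step lies within the scatter, so these two chain lengths cannot be told apart in this pair, and no information is available to explain this result.

As far as these compounds go, a longer chain such as 4-(dimethylamino)butyl, or another amine at the chain end such as morpholine or a primary amine, remains open, as only the dimethylamino end on these two chain lengths appears here. From the compounds shown here alone, it is also open whether the two chain lengths would still be indistinguishable with another ring on the urea, such as the 2-fluorophenyl of compound 1, which appears here only with the 3-(dimethylamino)propyl chain.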